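A few compounds are considered here, and "the series" means these few. Any claim that something is new, unique, unknown or untested is made for them only; others in the source may bear on it.

Working notes on the amide series.

All three measured compounds share one core and differ only in the group on the amide-type nitrogen. Compound 1 `COc1ccc(C(=O)Nc2cccc(Cl)c2Cl)cc1OC1CCCC1` carries a 2,3-dichlorophenyl there. In an assay on isolated protein for inhibition of phosphodiesterase 4A (Sus scrofa) (on this read-out higher numbers stand for weaker inhibition and lower numbers for stronger inhibition), compound 1 reaches only the limit > 200000 nM and no number; this is the case described in the limit of > 200000 nM in this assay, at which 1 of the 3 values shown sits. Compound 2 `COc1ccc(C(=O)Nc2c(F)cccc2F)cc1OC1CCCC1` carries a 2,6-difluorophenyl and in this assay compound 2 gives 70 nM. Compound 3 `COc1ccc(C(=O)Nc2c(Br)cncc2Br)cc1OC1CCCC1` carries a 3,5-dibromopyridin-4-yl and in this assay compound 3 gives 7 nM, the lowest of the two numbers in hand; the nearest is compound 2, through a 10-fold lower number from compound 2 to compound 3 (1.00 log units; beyond the scatter).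

The measured steps on this nitrogen are an at least 2800-fold lower number from compound 1 to compound 2 (3.45 log units; beyond the scatter), an at least 28000-fold lower number from compound 1 to compound 3 (4.45 log units; beyond the scatter) and a 10-fold lower number from compound 2 to compound 3 (1.00 log units; beyond the scatter), so the read-out moves strongly with the group at this position.

Compound 4 `COc1ccc(C(=O)NC2(C)C=C(C)ON2)cc1OC1CCCC1` is the next member: a group of 7 heavy atoms (5 carbon, 1 nitrogen, 1 oxygen; one five-membered non-aromatic ring with 2 hetero atoms) in place of a group of 8 heavy atoms (5 carbon, 1 nitrogen, 2 bromine; one six-membered aromatic ring with 1 hetero atom), on an amide-type nitrogen. Among the compounds with values here, no measured step replaces an aromatic ring at this position with a non-aromatic one, so the bearing of the three steps is indirect; they only show that the group here matters much. A higher number than compound 3 is expected, with wide uncertainty. For compound 4 in this assay the estimate is 1500 nM, between 100 nM and 30000 nM, an expected step of a 210-fold higher number from compound 3 to compound 4 (2.33 log units; beyond the scatter).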

Compound 4, half-maximal inhibitory concentration: 450 nM
Compound 4: the middle estimate sits 3.3-fold (0.52 log units) above what was measured; low and high end bracket the measured number.
By their numbers in this assay, from the lowest: compound 3; then compound 2; then compound 4. At a limit, above all of these: compound 1.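

Compound 4 shows that a non-aromatic ring on the amide-type nitrogen can still give a real number in this assay, with the step to this five-membered ring being a 64-fold higher number from compound 3 to compound 4 (1.81 log units; beyond the scatter) and, from the 2,6-difluorophenyl, a 6.4-fold higher number from compound 2 to compound 4 (0.81 log units; beyond the scatter). Against the 2,3-dichlorophenyl the same replacement gives an at least 440-fold lower number from compound 1 to compound 4 (2.64 log units; beyond the scatter), so among these four compounds ring aromaticity alone does not sort the read-out: the aromatic groups of compound 2 and compound 3 lie on one side of compound 4, and the aromatic group of compound 1 lies on the other. Compound 1 remains a limit and not a number: the limit of > 200000 nM in this assay, at which 1 of the 4 values shown sits.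

The single step to compound 4 changes ring size, aromaticity and hetero atoms together, so the compounds shown do not separate the share of each in its number. Also open, on these data alone, is how a piperidin-4-yl ring, an open tert-butyl group or a 3,5-dichloropyridin-4-yl group would read on this nitrogen, the last of these bearing on whether the two bromine atoms of compound 3 can be exchanged.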